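Dichloro versus monochloro core: benzyl chloride pair notes

The compounds below may be only part of what the source reports. "The series", "measured", "known", "first", "only" and "open" are said of these compounds alone.

Of the compounds shown here, two have been measured in a functional assay on MCF7 cells (Homo sapiens) for cytotoxicity, read by sulforhodamine B assay, with a stated time of 48 h (a higher number here means a weaker inhibitor of growth, a lower number a stronger inhibitor of growth), so far. Compound 1 `ClCc1ccc(Cn2cnc3c(Cl)ncnc32)cc1` gives 77600 nM in this assay. Compound 2 `ClCc1ccccc1Cn1cnc2c(Cl)nc(Cl)nc21` gives 1820 nM in this assay, the lowest of the two numbers and well beyond the scatter from compound 1. For the measured compounds named here, no step joining the two has been computed, since they differ in more than one place; their values show only that the two arrangements sit far apart.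

Compound 3 `ClCc1ccccc1Cn1cnc2c(Cl)ncnc21` is the next point. It differs from compound 2 by hydrogen in place of chloro on an aromatic carbon. Going by the values given here, no measured pair covers this change directly. Among the compounds with values here, the only other compound lacking this chloro, compound 1, carries its benzyl chloromethyl group elsewhere, so its value cannot be read as a guide to the step alone. The expectation is that the number rises, with a step of a 4.4-fold higher number from compound 2 to compound 3 (0.64 log units; beyond the scatter) estimated from compound 2 to compound 3. Compound 3 is accordingly expected to give 8000 nM in this assay, within a range from 2000 nM to 40000 nM.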

Compound 3, concentration for total growth inhibition: > 100000 nM
Compound 3 gave a limit, no number; the forecaster's own chance of this, stated with the estimate: 10%; middle value at least 12-fold (1.09 log units) away from the limit.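

Compound 3 in this assay gives a limit of the assay and not a number: the limit of > 100000 nM in this assay, at which 1 of the 3 values shown sits.

Hydrogen in place of chloro on the aromatic carbon between two ring nitrogen atoms gives an at least 54-fold higher number from compound 2 to compound 3 (1.73 log units; beyond the scatter), the first single-place comparison in the series. The earlier compounds shown here could not separate this chloro from the placing of the chloromethyl group, whereas this pair holds the benzyl chloride arrangement fixed and shows that growth inhibition depends strongly on the group at this position. As the step rests on a limit, it gives a bound on the size of the change and not a measured size.

The compounds shown leave open whether chloro itself is required at this position or whether another group there, such as an amine or a methoxy group, would keep a measurable number. They also leave open whether the chloro step carries over to the arrangement of compound 1, which has no partner bearing the second chloro among the compounds shown.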